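Chloro in place of methoxy on compound 1

The source may hold more compounds than are shown below. What is called first, only, known or untested is meant among the compounds shown, and "the series" means these compounds.

Compound 1 `C#CCNC(=O)/C(C)=C(\C)c1ccc(OC)cc1` gives 112 mg/kg in a functional assay on the whole organism (strain Icem-CET (SPF Caw)) for inhibition, with Mus musculus as the target, with a stated time of 30 min; a lower number here means that less compound is needed, a higher number that more compound is needed for the effect. Of the two numbers recorded so far it holds the upper one, but compound 2 `C/C(C(=O)NC1CC1)=C(/C)c1ccccc1`, which gives 55.9 mg/kg in this assay, sits within the scatter of it, so the two are not told apart. Compound 3 `C#CCNC(=O)/C(C)=C(\C)c1ccc(Cl)cc1` differs from compound 1 by chloro in place of methoxy on an aromatic carbon. Going by the values given here, no measured pair carries this change, so its size and direction are open; the step of a 1.2-fold lower number from compound 1 to compound 3 (0.09 log units; within the scatter) is expected to stay within the scatter. For compound 3 the expected value is 90 mg/kg, with a range from 45 mg/kg to 180 mg/kg.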

Compound 3, dose for half-maximal effect: 10.6 mg/kg
Compound 3: the middle estimate sits 8.5-fold (0.93 log units) above what was measured; measured number below the stated range.
By their numbers in this assay, from the lowest: compound 3; then compounds 2 and 1 (each within the scatter of the next).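

In this assay, the group on this aromatic carbon, para to a large group, proves to have a strong bearing on the dose needed: chloro in place of methoxy gives an 11-fold lower number from compound 1 to compound 3 (1.02 log units; beyond the scatter), a step beyond the scatter. Going by these compounds alone, this is the first measured pair, and it sets compound 3 apart from compound 1 on the one change. No measurement at hand accounts for the size of this step.

As far as these compounds go, whether bromo, fluoro or trifluoromethyl on this carbon would match chloro remains open. So does whether the step would hold with a cyclopropyl group in place of the chain on the amide nitrogen.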